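Series notes: pentyl in place of fluoro, compound 3 to compound 4

The source may report more compounds than this note shows. Statements on the series, on what has been measured and on what is new or still open speak of the compounds shown alone.

Measured compounds:
Compound 1 `COc1cc(/C=C/C(=O)c2cccc(-n3cc(-c4ccc(F)cc4)nn3)c2)ccc1O` gives 6450 nM in a functional assay on RAW264.7 cells (Mus musculus) for inhibition, with a stated time of 4 days; on this read-out lower numbers stand for stronger inhibition and higher numbers for weaker inhibition.
Compound 2 `COc1ccc(/C=C/C(=O)c2cccc(-n3cc(C(C)(C)O)nn3)c2)cc1O` gives 17100 nM in this assay.
Compound 3 `COc1ccc(/C=C/C(=O)c2cccc(-n3cc(-c4ccc(F)cc4)nn3)c2)cc1O` gives 2500 nM in this assay.

Compound 3 holds the lowest number of the three, and both of its steps lie beyond the scatter: a 2.6-fold lower number from compound 1 to compound 3 (0.41 log units; beyond the scatter) and a 6.8-fold lower number from compound 2 to compound 3 (0.84 log units; beyond the scatter). It is therefore the most potent of the measured set.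

Compound 4 `CCCCCc1ccc(-c2cn(-c3cccc(C(=O)/C=C/c4ccc(OC)c(O)c4)c3)nn2)cc1` differs from compound 3 in one place: pentyl in place of fluoro on an aromatic carbon. Among the measured compounds shown here, no measured step touches this position. The step from compound 2 to compound 3 shows that the group on that aromatic carbon of the triazole can move the number by a modest amount, but that step exchanged a 1-hydroxy-1-methylethyl for a 4-fluorophenyl, not one substituent on the 4-fluorophenyl for another. With nothing directly comparable, the expectation for compound 4 is a number close to that of compound 3, with any step likely within or only slightly beyond the scatter and the direction uncertain; the estimated step is a 1.2-fold higher number from compound 3 to compound 4 (0.08 log units; within the scatter). Compound 4 is expected to give 3000 nM in this assay, with a range from 800 nM to 12000 nM.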

Compound 4, half-maximal inhibitory concentration: > 30000 nM
Compound 4 gave a limit, no number; the forecaster's own chance of this, stated with the estimate: 10%; at least 10-fold (1.00 log units) between middle value and limit.
By their numbers in this assay, from the lowest: compound 3; then compound 1; then compound 2. At a limit, above all of these: compound 4.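

Compound 4 stands at a limit of the read-out, not at a number: the limit of > 30000 nM in this assay, at which 1 of the 4 values shown sits. Among the compounds shown here, the substituent on this aromatic carbon therefore matters in its own right, since the change from 4-fluorophenyl to 4-pentylphenyl gives an at least 12-fold higher number from compound 3 to compound 4 (1.07 log units; beyond the scatter), whereas the earlier steps showed only that exchanging the whole group could move the number. Against the 1-hydroxy-1-methylethyl group, the reading is an at least 1.7-fold higher number from compound 2 to compound 4 (0.24 log units; that floor lies within the scatter), so this floor alone does not separate the two groups, and a phenyl group at this place does not by itself secure the lower number.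

On these data alone, whether the rise follows the length of the pentyl chain or the loss of fluoro stays open. A methyl or ethyl group, or an amine or a carboxylic acid, at the same carbon would help separate these readings.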